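A few compounds are considered here, and "the series" means these few. Any claim that something is new, unique, unknown or untested is made for them only; others in the source may bear on it.

Three compounds with a methyl on the same aromatic carbon of the shared core have been tested in a functional assay on the whole organism (Myocardium) with Canis familiaris (Canis lupus familiaris) as the target, at a dose of 8.75 mg/kg by the intravenous route; on this read-out lower numbers stand for an effect already at smaller amounts and higher numbers for an effect only at larger amounts of compound. They differ only in the other groups on that core. Compound 1 (`Cc1nc(O)nc2ccc(Cl)cc12`) gives 1.8 mg/kg, compound 3 (`COc1cc(OC)c2c(C)nc(O)nc2c1`) gives 2.08 mg/kg, and compound 2 (`COc1cc2nc(O)nc(C)c2cc1OC`) gives 2.42 mg/kg. Compound 2 therefore stands level with the other two, as its number lies within the usual scatter of both, and the three cannot be ranked.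

The next compound to be tested is compound 4 (`COc1cc2nc(O)nc(C3CCCC3)c2cc1OC`), which keeps everything in compound 2 except one group: cyclopentyl in place of methyl on an aromatic carbon. In words, this is cyclopentyl in place of methyl on an aromatic carbon. Going by the values given here, no measured pair shows what happens when this methyl is replaced, so the expectation rests on thin ground. The incoming group is clearly bigger, and a change of that size seems more likely to raise the dose needed than to lower it, though only moderately. The estimated 1.7-fold higher number from compound 2 to compound 4 (0.22 log units; within the scatter) is expected to point toward a higher number and to be close to the size of the scatter. For compound 4 the estimate is 4 mg/kg, with an expected range from 1.5 mg/kg to 10 mg/kg.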

Compound 4, dose for half-maximal effect: > 8.75 mg/kg
Compound 4 ended at the assay's limit; the forecaster's own chance of this, stated with the estimate: 20%; middle value at least 2.1-fold (0.33 log units) away from the limit.
By their numbers in this assay, from the lowest: compounds 1, 3 and 2 (each within the scatter of the next). At a limit, above all of these: compound 4.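

In this assay, cyclopentyl in place of methyl on an aromatic carbon gives an at least 3.6-fold higher number from compound 2 to compound 4 (0.55 log units; beyond the scatter), so a larger dose is needed for the effect once the methyl is gone. The three earlier compounds all carry methyl on this carbon and differ only in their other groups, so they could not show that the group here matters; this step shows that the read-out does respond to a change on this carbon, next to the ring nitrogen. Compound 4 gives > 8.75 mg/kg, which is a limit of the assay and not a number, so the step sets only a lower bound on the change: the limit of > 8.75 mg/kg in this assay, at which 1 of the 4 values shown sits.

On these data alone, how far the number rises remains open, as does whether the rise follows the ring itself or simply the larger group, which an open chain such as ethyl or n-pentyl on the same carbon would help to separate. Also open, as far as these compounds go, is how an amine or a phenyl group would behave on this carbon, and whether cyclopentyl would have the same effect on the core of compound 1 or compound 3, which carry chloro and differently placed methoxy groups.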